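This account rests on a few compounds, and the source may have more. Where it says the series, first, only, none or still open, it means among the compounds named here.

Compound 1 `CC(C)(C)c1ccc(NC2=NCCO2)cc1`: 1500 nM
Compound 2 `O=C(CCl)NC(=O)Nc1ccc(-c2ccccc2)cc1`: 2300 nM
Compound 3 `O=C(CCl)NC(=O)Nc1cccc(Oc2ccccc2)c1`: 5200 nM

These three compounds were tested in a functional assay on HT-29 cells (Homo sapiens) for inhibition, read by sulforhodamine B assay, with a stated time of 48 h; on this read-out lower numbers stand for stronger inhibition of growth and higher numbers for weaker inhibition of growth. There, compound 2 gives 2300 nM, a number that lies within the usual scatter of compound 1 at 1500 nM. Compound 3, at 5200 nM, has a number higher than that of compound 2 by more than the scatter, and so shows weaker inhibition of growth.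

Compound 4 `O=C(CCl)NC(=O)Nc1ccc(I)cc1` has not yet been measured. It differs from compound 2 in one place: iodo in place of phenyl on an aromatic carbon.

For the measured compounds named here, no two measured compounds differ in just one place, so the data give no direct guide to the size of this change. The measured numbers run only from compound 1 at 1500 nM to compound 3 at 5200 nM, so a large step is not expected. The expected step is a 1.5-fold higher number from compound 2 to compound 4 (0.18 log units; within the scatter), a small move towards weaker inhibition of growth that probably stays within the scatter. For compound 4 the estimate in this assay is 3500 nM, with an expected range from 1500 nM to 8000 nM.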

Compound 4, concentration for 50% growth inhibition: 6900 nM
Compound 4: middle estimate off by 2.0-fold (0.29 log units), on the low side; measured number inside the range.
By their numbers in this assay, from the lowest: compounds 1 and 2 (each within the scatter of the next); then compounds 3 and 4 (each within the scatter of the next).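

In this assay, for the compounds shown here, the exchange of phenyl for iodo gives a 3.0-fold higher number from compound 2 to compound 4 (0.48 log units; beyond the scatter) and so provides the first direct reading of a single change. It shows that the group on this aromatic carbon, para to a group of 8 heavy atoms, matters to inhibition of growth: with the rest of the molecule unchanged, replacing the six-membered aromatic ring of carbon only with a single iodine atom weakens inhibition beyond the usual scatter. Going by these compounds alone, neither group carries a hydrogen-bond donor, a hydrogen-bond acceptor or a net charge, so the step accompanies a change that these counts do not distinguish, and the single pair cannot separate the loss of the phenyl ring from the arrival of iodine. No measurement offered here accounts for the step.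

Open, going by these compounds, is how other groups would behave at this position, such as a hydrogen, a methoxy group, an amine, a carboxylic acid or a longer chain. Also open, on these data alone, is whether the same exchange would give a step of similar size on another core, or with the chloroacetyl part replaced by another acyl group.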